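Swapping the side group on the shared core: solubility outlook

The source may hold more compounds than are shown below. What is called first, only, known or untested is meant among the compounds shown, and "the series" means these compounds.

Three compounds share one core and differ only in the group carried on a saturated chain carbon bound to an aromatic carbon and a saturated chain carbon. In a physicochemical assay for solubility, measured as kinetic solubility, at pH 2 (on this read-out higher numbers stand for higher solubility and lower numbers for lower solubility), compound 1 `CC(C)NC(=O)CC(c1ccc(-c2ccc3cccc(F)c3c2)[nH]c1=O)C(C)C` gives 24200 nM. In this assay compound 2 `CC(C)C(Nc1nccs1)c1ccc(-c2ccc3cccc(F)c3c2)[nH]c1=O` gives 32900 nM, and compound 3 `CC(C)C(Cc1ncc[nH]1)c1ccc(-c2ccc3cccc(F)c3c2)[nH]c1=O` gives 33800 nM. Compound 3 sits within the scatter of both others: the steps were a 1.4-fold higher number from compound 1 to compound 3 (0.15 log units; within the scatter) and a 1.0-fold higher number from compound 2 to compound 3 (0.01 log units; within the scatter), and the remaining pair showed a 1.4-fold higher number from compound 1 to compound 2 (0.13 log units; within the scatter).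

Compound 4 `CC(C)C(c1ccc(-c2ccc3cccc(F)c3c2)[nH]c1=O)N1CCN/C1=N\C#N` continues this series with a group of 8 heavy atoms (4 carbon, 4 nitrogen; one five-membered non-aromatic ring with 2 hetero atoms) in place of a group of 6 heavy atoms (4 carbon, 2 nitrogen; one five-membered aromatic ring with 2 hetero atoms), on a saturated chain carbon bound to an aromatic carbon and a saturated chain carbon. All three earlier swaps at this same position left the number within the scatter, so the expectation is that the move to compound 4 again brings no step beyond the scatter, estimated as a 1.1-fold lower number from compound 3 to compound 4 (0.05 log units; within the scatter). Compound 4 is therefore expected to give about 30000 nM, with a range from 15000 nM to 60000 nM.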

Compound 4, solubility: 32500 nM
Compound 4: middle estimate off by 1.1-fold (0.03 log units), on the low side; the measured number falls inside the stated range.
By their numbers in this assay, from the lowest: compounds 1, 4, 2 and 3 (each within the scatter of the next).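

In this assay this position now also takes a five-membered non-aromatic ring with a double bond and a triple bond outside aromatic rings, and the number stays within the scatter of the group it replaces (a 1.0-fold lower number from compound 3 to compound 4 (0.02 log units; within the scatter)). The same holds against the thiazole-bearing group (a 1.0-fold lower number from compound 2 to compound 4 (0.01 log units; within the scatter)) and against the open-chain amide group (a 1.3-fold higher number from compound 1 to compound 4 (0.13 log units; within the scatter)), so neither a ring that is not aromatic nor the larger group of 8 heavy atoms separates compound 4 from the other three compounds. No measurement is at hand that could explain this flat result.

Going by these compounds, whether a basic amine such as piperidine or a carboxylic acid at this position would step beyond the scatter stays open. So does whether a longer chain between this carbon and the ring would do so.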